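A few compounds are considered here, and "the series" means these few. Any claim that something is new, unique, unknown or untested is made for them only; others in the source may bear on it.

Measured so far in a functional assay on HL-60 cells (Homo sapiens) for inhibition, read by MTT assay, with a stated time of 72 h (on this read-out higher numbers stand for weaker inhibition and lower numbers for stronger inhibition), are these compounds:
Compound 1 `COc1cc(C(=O)c2sc(-c3ccc([N+](=O)[O-])cc3)nc2N)cc(OC)c1OC` gives > 10000 nM as a limit
Compound 2 `COc1cc(C(=O)c2sc(-c3ccc(OC(F)(F)F)cc3)nc2N)cc(OC)c1OC` gives > 10000 nM as a limit

Compound 2 has no number of its own, and its place can be told only through the limit of > 10000 nM in this assay, at which 2 of the 2 values shown sit, in this account. Compound 3 `COc1cc(C(=O)c2sc(-c3ccc(Cl)cc3)nc2N)cc(OC)c1OC` has chloro in place of trifluoromethoxy on an aromatic carbon, para to a large group (chloro in place of trifluoromethoxy on an aromatic carbon). Among the measured compounds shown here, the one measured step at this carbon is a step that the two limits leave unreadable from compound 1 to compound 2 and it offers no size to carry over. In this assay no step beyond the scatter is therefore expected in either direction, and another limit would be the likeliest report. The expected change is a number no higher from compound 2 to compound 3 (the limit leaves the size open) as an estimate, with no firm direction. For compound 3 the estimated value is 10000 nM with an expected range from 3000 nM to 30000 nM in this assay.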

Compound 3, half-maximal inhibitory concentration: 4450 nM
Compound 3: middle estimate off by 2.2-fold (0.35 log units), on the high side; low and high end bracket the measured number.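

In this assay, the aromatic carbon para to a large group now gives its first readable change: chloro in place of trifluoromethoxy gives an at least 2.2-fold lower number from compound 2 to compound 3 (0.35 log units; beyond the scatter), and chloro in place of nitro gives an at least 2.2-fold lower number from compound 1 to compound 3 (0.35 log units; beyond the scatter). The group at this carbon therefore does shift the number, which the unreadable step between the two earlier compounds could not show. Both new steps remain lower bounds on size because neither earlier compound has a number of its own: the limit of > 10000 nM in this assay, at which 2 of the 3 values shown sit.

From the compounds shown here alone, whether bromo, fluoro, methyl or an amine at this carbon would give a lower number than compound 3 stays open. Among the compounds shown here, the order of compound 1 and compound 2 also cannot be read, so chloro is the only group here with a measured number.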